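The source may report more compounds than this note shows. Statements on the series, on what has been measured and on what is new or still open speak of the compounds shown alone.

Working notes on the series, values from a physicochemical assay for lipophilicity, read by HPLC, measured as chromatographic lipophilicity, at pH 7.4; on this read-out higher numbers stand for higher lipophilicity and lower numbers for lower lipophilicity:

- compound 1 `O=C(c1cscn1)N1CCC(C(=O)N2N=CC[C@H]2c2ccccc2)CC1`: 3
- compound 2 `CC(C)(C)C(=O)N1CCNCC1c1ccccc1`: 2.5
- compound 3 `O=C(c1cccnc1)N1CCC(C(=O)N2N=CCC2c2ccccc2)CC1`: 2.6

Compound 2 has the lowest number of the three at 2.5, but its nearest neighbour, compound 3 at 2.6, lies within the scatter of it. Only compound 1, at 3, stands higher than compound 2 by more than the scatter.

The next compound to be measured is compound 4 `CN1CCN(C(=O)C(C)(C)C)C(c2ccccc2)C1`. It departs from compound 2 by one change: methyl in place of hydrogen on an amine nitrogen in a ring. In words, this is methyl in place of hydrogen on an amine nitrogen in a ring.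

Among the measured compounds shown here, no two measured compounds differ in one place only, so the series offers no direct measure of this change. The expectation therefore starts from compound 2 at 2.5 and rests on the structural change alone, with wide margins. A small upward movement in this assay is expected, and the estimated size is a number 0.40 log units higher from compound 2 to compound 4 (beyond the scatter). A result within the scatter of compound 2 would not be surprising.

For compound 4 the estimated value is 2.9, with an expected range from 2.5 to 3.3.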

Compound 4, distribution coefficient: 4.9
Compound 4: middle estimate off by 2.00 log units, on the low side; the whole stated range lies below it.
By their numbers in this assay, from the lowest: compounds 2 and 3 (each within the scatter of the next); then compound 1; then compound 4.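

In this assay, the series now has its first direct comparison of compounds that differ in one place: a number 2.40 log units higher from compound 2 to compound 4 (beyond the scatter), a large step for methyl in place of hydrogen on an amine nitrogen in a ring. Among the compounds shown here, this is the first reading at this position, on the six-membered non-aromatic ring with 2 nitrogen, two ring bonds from the ring atom that bears a phenyl group, and it shows that 1 heavy atom entering here can move the read-out well beyond the scatter. For the compounds shown here, nothing measured so far accounts for the size of this step.

This single step leaves open whether its size belongs to methyl alone or would also appear with another replacement for that hydrogen, such as ethyl, a longer chain or an acetyl group on the same nitrogen. It also leaves open whether the same change on an amine nitrogen in a different ring would give a step of similar size, since one pair establishes no pattern.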